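The source may hold more compounds than are shown below. What is called first, only, known or untested is meant among the compounds shown, and "the series" means these compounds.

Measured compounds in an ADME assay on MCF-10A cells (Homo sapiens) for inhibition, with a stated time of 48 h; on this read-out higher numbers stand for weaker inhibition and lower numbers for stronger inhibition:

Compound 1 `Cc1cccc(-c2noc([C@@H]3CCCN3C(=O)Nc3ccc(Cl)cc3)n2)c1` gives > 50000 nM, which is a limit of the assay.
Compound 2 `O=C(Nc1ccc(Cl)cc1)N1CCC[C@H]1c1nc(-c2cccc(F)c2)no1` gives > 50000 nM, again a limit.
Compound 3 `Cc1ccc(-c2noc([C@@H]3CCCN3C(=O)Nc3ccc(Cl)cc3)n2)cc1` gives > 50000 nM, also a limit.

All three values sit at the limit of > 50000 nM in this assay, at which 3 of the 3 values shown sit, so the step from compound 1 to compound 2, (fluoro in place of methyl on an aromatic carbon), reads as a step that the two limits leave unreadable from compound 1 to compound 2. Compound 4 `O=C(Nc1ccc(Cl)cc1)N1CCC[C@H]1c1nc(-c2ccc(F)cc2)no1` is not yet measured; it differs from compound 3 by fluoro in place of methyl on an aromatic carbon. This is the same kind of change as from compound 1 to compound 2, but the place differs: in the earlier pair the position is meta to a large group, here it is para to a large group. The two cores differ by 4-methylphenyl in place of 3-methylphenyl on an aromatic carbon.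

For compound 4 the step that the limit leaves unreadable from compound 3 to compound 4 is expected to be unreadable as well, resting on compound 3 at > 50000 nM and on (the limit of > 50000 nM in this assay, at which 3 of the 3 values shown sit). Compound 4 is estimated at 60000 nM in this assay, most likely reported only as a limit.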

Compound 4, half-maximal inhibitory concentration: > 50000 nM
Compound 4 ended at the assay's limit; the forecaster's own chance of this, stated with the estimate: 85%; the middle value is on the limit's open side.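

The steps among compound 1, compound 2, compound 3 and compound 4 cannot be read: the limit of > 50000 nM in this assay, at which 4 of the 4 values shown sit.
Left open in this assay is how far each of these four compounds lies from that limit, and whether any change to the shared core gives a measurable value.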